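Ethylamino in Place of Methylpiperazine on the Shared Core

A few compounds are considered here, and "the series" means these few. Any claim that something is new, unique, unknown or untested is made for them only; others in the source may bear on it.

Compound 1 `CN1CCN(c2nc(NCc3ccc(NC(=O)c4ccc(F)cc4)cc3)c3ccccc3n2)CC1` gives 2500 nM in a functional assay on SW480 cells (Homo sapiens) for inhibition, read by luminescence and resazurin assay, with a stated time of 3 days; a higher number here means a weaker inhibitor, a lower number a stronger inhibitor. Compound 2 `CN1CCN(c2nc(NCc3ccc(NC(=O)c4ccncc4)cc3)c3ccccc3n2)CC1` gives > 20000 nM, which is a limit of the assay. Compound 3 `Cc1ccc(S(=O)(=O)Nc2ccc(CNc3nc(N4CCN(C)CC4)nc4ccccc34)cc2)cc1` gives > 20000 nM, also a limit.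

Among the compounds with values here, compound 1 thus holds the only number in this assay; the other two values sit at the limit of > 20000 nM in this assay, at which 2 of the 3 values shown sit. The measured steps, an at least 8.0-fold higher number from compound 1 to compound 2 (0.90 log units; beyond the scatter) and an at least 8.0-fold higher number from compound 1 to compound 3 (0.90 log units; beyond the scatter), both alter the amide end of the molecule. Compound 4 `CCNc1nc(NCc2ccc(NC(=O)c3ccc(F)cc3)cc2)c2ccccc2n1` changes a different place: ethylamino in place of 4-methylpiperazin-1-yl on an aromatic carbon. Within the data shown here, no measured step touches this position, so no measured step bears on it, and the direction of the step is open. The account expects a modest loss, a 2.0-fold higher number from compound 1 to compound 4 (0.30 log units; within the scatter), and estimates for compound 4 a value of 5000 nM, within 1500 nM to 20000 nM.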

Compound 4, half-maximal inhibitory concentration: 2300 nM
Compound 4: the middle estimate sits 2.2-fold (0.34 log units) above what was measured, and the stated range covers the measured number.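

At the aromatic carbon between two ring nitrogen atoms, ethylamino in place of 4-methylpiperazin-1-yl gives a 1.1-fold lower number from compound 1 to compound 4 (0.04 log units; within the scatter) in this assay. The 4-methylpiperazin-1-yl ring can therefore be replaced here without a change beyond the scatter, whereas both readable steps at the amide end were beyond it. Nothing available here accounts for this step.

On these data alone, whether an unsubstituted amine, a longer chain such as butylamino, or a morpholine ring at this position would give a similar number remains open. So does whether ethylamino would behave alike alongside the pyridin-4-yl amide of compound 2.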